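The compounds below may be only part of what the source reports. "The series", "measured", "known", "first", "only" and "open" are said of these compounds alone.

Of the compounds shown here, three bearing the same naphthyloxy-acetohydrazide core have been measured in an ADME assay on MT4 cells (Homo sapiens) for cytotoxicity, read by MTT assay, with a stated time of 4 days; on this read-out higher numbers stand for lower toxicity in this test and lower numbers for higher toxicity in this test. Compound 2, `O=C(COc1cccc2ccccc12)N/N=C/c1ccc(Cl)cc1`, gives 87.6 ug/mL. Compound 1, `CCOc1ccc(/C=N/NC(=O)COc2cccc3ccccc23)cc1O`, gives 6.23 ug/mL, and compound 3, `C/C(=N\NC(=O)COc1cccc2ccccc12)c1cccc([N+](=O)[O-])c1`, gives 12.1 ug/mL. Compound 2 thus stands highest of the three numbers; compound 3 is nearest, with a gap beyond the scatter, and compound 1 lies furthest, also beyond the scatter.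

Compound 4, `O=C(COc1cccc2ccccc12)N/N=C/c1cccc(O)c1`, has not yet been measured in this assay . Relative to compound 2 it carries 3-hydroxyphenyl in place of 4-chlorophenyl on a carbon with a double bond to nitrogen. Among the measured compounds shown here, no pair of measured compounds differs at this one place only, so no measured step serves as a template. What is known is that compound 1, which also bears a hydroxyl on the aryl ring beside an ethoxy group, sits at 6.23 ug/mL, far under compound 2. On that basis compound 4 is expected to move in this assay toward a lower number than compound 2, by a step of a 2.9-fold lower number from compound 2 to compound 4 (0.47 log units; beyond the scatter), because compound 1 shows 6.23 ug/mL and compound 3 shows 12.1 ug/mL while only compound 2 reaches a high value. Compound 4 is therefore estimated at 30 ug/mL, with a plausible range from 8 ug/mL to 100 ug/mL.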

Compound 4, half-maximal cytotoxic concentration: 32.6 ug/mL
Compound 4: the middle estimate sits 1.1-fold (0.04 log units) below what was measured; the range from low to high includes it.
By their numbers in this assay, from the lowest: compounds 1 and 3 (each within the scatter of the next); then compound 4; then compound 2.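

In this assay, among the compounds shown here, 3-hydroxyphenyl in place of 4-chlorophenyl on a carbon with a double bond to nitrogen gives a 2.7-fold lower number from compound 2 to compound 4 (0.43 log units; beyond the scatter), the first comparison that isolates this one place and shows that the number responds to the change. Hydrogen in place of ethoxy on an aromatic carbon gives a 5.2-fold higher number from compound 1 to compound 4 (0.72 log units; beyond the scatter), so a hydroxyl on the aryl ring does not by itself bring a compound as low as compound 1, and the ring's other substituent also matters to the number. Nothing measured on these compounds speaks to why either step arises.

The step from 4-chlorophenyl to 3-hydroxyphenyl changes both the substituent and where it stands on the ring, and the compounds shown cannot separate these two changes. They also leave open how the number would move with an amine or a carboxylic acid in place of the hydroxyl of 3-hydroxyphenyl, or with a longer chain in place of the ethoxy group of compound 1.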